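From Cyclopropyl Ester to Ethyl Ketone: Expected Lipophilicity

A few compounds are considered here, and "the series" means these few. Any claim that something is new, unique, unknown or untested is made for them only; others in the source may bear on it.

Compound 1 `CC(/C=C/CC(C)CCCC(C)C)=C\C(=O)Oc1ccccc1`: 7.67
Compound 2 `COC(C)(C)CCCC(C)C/C=C/C(C)=C/C(=O)OC1CC1`: 5.71
Compound 3 `C=CCSC(=O)/C=C(C)/C=C/CC(C)CCCC(C)C`: 7.97

In a physicochemical assay for lipophilicity (on this read-out lower numbers stand for lower lipophilicity and higher numbers for higher lipophilicity), compound 2 gives the lowest of the three values, with compound 1 nearer to it and compound 3 further away, both beyond the scatter. Compound 4 `CCC(=O)/C=C(C)/C=C/CC(C)CCCC(C)(C)OC` is the unmeasured neighbour of compound 2; the change is ethyl in place of cyclopropyloxy on a carbonyl carbon. Among the measured compounds shown here, the one measured step at a carbonyl carbon is a number 0.30 log units higher from compound 1 to compound 3 (within the scatter), which swaps two different groups and so bears on this case only loosely. Removing the ring oxygen while shortening the group suggests a small move, and the estimated step is a number 0.36 log units lower from compound 2 to compound 4 (beyond the scatter). Compound 4 is therefore expected at 5.35, within 4.75 to 5.95.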

Compound 4, partition coefficient: 5.07
Beside the measured number, compound 4's estimate is 0.28 log units above it; the measured number falls inside the stated range.
By their numbers in this assay, from the lowest: compound 4; then compound 2; then compounds 1 and 3 (each within the scatter of the next).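

On this carbonyl carbon, ethyl in place of cyclopropyloxy gives in this assay a number 0.64 log units lower from compound 2 to compound 4 (beyond the scatter) and leaves compound 4 with the lowest number of the set. The earlier step at a carbonyl carbon was a number 0.30 log units higher from compound 1 to compound 3 (within the scatter) and could not be told apart from repeat noise, whereas this one shows that the group on this carbon can shift the number measurably. Still open, as far as these compounds go, is how a longer chain such as butyl, or an amine, would read at the same carbon. No measurement available here accounts for the size of this step.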